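The compounds below may be only part of what the source reports. "The series", "measured", "known", "first", "only" and "open" are said of these compounds alone.

Measured compounds:
Compound 1, `COc1cc2c(cc1OC)C(CC(=O)O)CC2`: 18.8%
Compound 2, `CNC(=O)CC1CCc2cc(OC)c(OC)cc21`: 15.6%
Compound 3, `CCCCCNC(=O)CC1CCc2cc(OC)c(OC)cc21`: 34.4%

Three compounds sharing one core were tested in a functional assay on the whole organism (strain Wistar) for inhibition, with Rattus norvegicus as the target, read by paw edema, with stated times of 60 min and 1 h, at a dose of 100 mg/kg by the oral route; on this read-out higher numbers stand for more inhibition at the one dose given (going by the name of the read-out) and lower numbers for less inhibition. Compound 1 gives 18.8%, compound 2 gives 15.6% and compound 3 gives 34.4%. Compound 3 stands highest of the three, beyond the scatter from both others. The steps leading to it are a number 15.6 percentage points higher from compound 1 to compound 3 (beyond the scatter) and a number 18.8 percentage points higher from compound 2 to compound 3 (beyond the scatter), while a number 3.2 percentage points lower from compound 1 to compound 2 (within the scatter) stays within the scatter.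

Compound 4, `COc1cc2c(cc1OC)C(CC(=O)NCc1ccccc1)CC2`, has not been measured in this assay . It differs from compound 3 by phenyl in place of butyl on a saturated chain carbon bound to an amide-type nitrogen. Among the compounds with values here, no measured pair shows a swap of one chain for a ring, so the only bearing steps are those into compound 3: both gains there came from growing the group on the amide-type nitrogen from hydrogen or methyl to a longer chain. Compound 4 keeps a group of comparable size in that place, so the expected step is a number 2.4 percentage points lower from compound 3 to compound 4 (within the scatter), no more than the scatter in either direction. Compound 4 is therefore estimated at 32%, with a range from 18% to 46%.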

Compound 4, a percentage reported as inhibition, in the whole organism at one dose (the size of the read-out at that dose, not a potency): 18.8%
For compound 4 the middle estimate is 13.2 percentage points above the measured one; the range from low to high includes it.
By their numbers in this assay, from the lowest: compounds 2, 1 and 4 (each within the scatter of the next); then compound 3.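

In this assay, phenyl in place of butyl on a saturated chain carbon bound to an amide-type nitrogen gives a number 15.6 percentage points lower from compound 3 to compound 4 (beyond the scatter), so the gain seen in compound 3 does not carry over to the benzylamino amide. That amide stays level with the other two compounds, with a number 3.2 percentage points higher from compound 2 to compound 4 (within the scatter) and no change at the digits printed from compound 1 to compound 4 (within the scatter), which shows that pentylamino and benzylamino are not interchangeable at this position. Nothing available here gives a reason for this difference.

Whether the gain follows chain length cannot be settled from methyl and pentyl alone, and a propyl or hexyl chain on the amide nitrogen would bear on that. From the compounds shown here alone, it also remains open whether a phenethyl or cyclohexylmethyl group would behave like benzyl or like pentyl.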